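Replacing the para ethoxy of compound 3 with methoxycarbonyl

The compounds below may be only part of what the source reports. "The series", "measured", "known", "first", "only" and "open" are said of these compounds alone.

Measured so far in an assay on isolated protein for inhibition of Rho-associated protein kinase 1 (Homo sapiens), read by scintillation counting, radiometric assay and 33P incorporation, with a stated time of 40 min, in the presence of a further agent that is not named here; on this read-out higher numbers stand for weaker inhibition and lower numbers for stronger inhibition:
compound 1 `O=C(COc1ccc2c(=O)ccoc2c1)Nc1cccc(NC(=O)c2ccccc2)c1` gives 120 nM
compound 2 `Cc1ccc(C(=O)Nc2cccc(NC(=O)COc3ccc4c(=O)ccoc4c3)c2)cc1` gives 183 nM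
compound 3 `CCOc1ccc(C(=O)Nc2cccc(NC(=O)COc3ccc4c(=O)ccoc4c3)c2)cc1` gives 17 nM

Compound 3 stands lowest of the three numbers; the step from compound 1 to compound 3 reads a 7.1-fold lower number from compound 1 to compound 3 (0.85 log units; beyond the scatter), and from compound 2 to compound 3 an 11-fold lower number from compound 2 to compound 3 (1.03 log units; beyond the scatter), both beyond the scatter. The step from compound 1 to compound 2, a 1.5-fold higher number from compound 1 to compound 2 (0.18 log units; within the scatter), is within the scatter.

Compound 4 `COC(=O)c1ccc(C(=O)Nc2cccc(NC(=O)COc3ccc4c(=O)ccoc4c3)c2)cc1` is not yet measured. It differs from compound 3 by methoxycarbonyl in place of ethoxy on an aromatic carbon. Going by the values given here, no measured step covers this exchange; the steps that bear on it only show that a group at this aromatic carbon shifts the number beyond the scatter, as ethoxy did against hydrogen and methyl, while methoxycarbonyl is a different group with more acceptors. The step from compound 3 to compound 4 is therefore expected to be a 3.5-fold higher number from compound 3 to compound 4 (0.55 log units; beyond the scatter), with wide uncertainty. Compound 4 is estimated at 60 nM, within 15 nM to 250 nM.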

Compound 4, half-maximal inhibitory concentration: 72 nM
Estimate against measurement, compound 4: 1.2-fold (0.08 log units) below, and the stated range covers the measured number.
By their numbers in this assay, from the lowest: compound 3; then compounds 4, 1 and 2 (each within the scatter of the next, the first and the last beyond it).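

Methoxycarbonyl on this aromatic carbon, para to a large group, does not hold the level reached with ethoxy, giving a 4.2-fold higher number from compound 3 to compound 4 (0.63 log units; beyond the scatter) even though it carries more hydrogen-bond acceptors. Against the simpler groups it reads a 2.5-fold lower number from compound 2 to compound 4 (0.41 log units; beyond the scatter) for methyl and a 1.7-fold lower number from compound 1 to compound 4 (0.22 log units; within the scatter) for hydrogen, so it separates from methyl but not from hydrogen, and ethoxy remains the only group here clearly apart from hydrogen. Nothing available here accounts for the difference between ethoxy and methoxycarbonyl.

Two groups containing oxygen at this carbon cannot show whether the result for ethoxy follows from its ether oxygen, its ethyl chain or both. Methoxy, a longer chain such as propoxy, a carboxylic acid and an amine at the same carbon remain open.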